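Heterocycle swap at the chain end, compound 1 to compound 4

A few compounds are considered here, and "the series" means these few. Any claim that something is new, unique, unknown or untested is made for them only; others in the source may bear on it.

In a functional assay on MCF7 cells (Homo sapiens) for inhibition, read by MTT assay, with a stated time of 72 h (on this read-out higher numbers stand for weaker inhibition and lower numbers for stronger inhibition), compound 1 `O=C1O/C(=C\Cn2ncc(=O)[nH]c2=O)C(OCc2ccccc2)=C1OCc1ccccc1` gives 3770 nM. Among the three measured compounds this is the second highest number: compound 2 `O=C1O/C(=C\Cn2ccc(NC(=O)c3ccccc3)nc2=O)C(OCc2ccccc2)=C1OCc1ccccc1` gives 2030 nM in this assay, and compound 3 `O=C1O[C@H]([C@@H](O)Cn2ccc(NC(=O)c3ccccc3)nc2=O)C(OCc2ccccc2)=C1OCc1ccccc1` gives 4790 nM. The gap from compound 1 to either of the others lies within the scatter, so no order among the three can be read from these numbers.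

Compound 4 `O=C1O/C(=C\Cn2c(=O)[nH]c(=O)[nH]c2=O)C(OCc2ccccc2)=C1OCc1ccccc1` is not yet measured. It differs from compound 1 by a group of 9 heavy atoms (3 carbon, 3 nitrogen, 3 oxygen; one six-membered aromatic ring with 3 hetero atoms) in place of a group of 8 heavy atoms (3 carbon, 3 nitrogen, 2 oxygen; one six-membered aromatic ring with 3 hetero atoms), on a saturated chain carbon bound to a double-bonded chain carbon. Among the measured compounds shown here, no step between two measured compounds matches this change, so nothing in the set shows directly what this exchange of the ring does. The three measured compounds, which differ from one another in the group at the chain end and in the chain itself, all sit within the scatter of one another, which gives no ground to expect a move beyond the scatter in either direction. The step from compound 1 to compound 4 is expected to be small, a 1.1-fold higher number from compound 1 to compound 4 (0.03 log units; within the scatter). Compound 4 is estimated at 4000 nM, with a range from 1500 nM to 11000 nM.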

Compound 4, half-maximal inhibitory concentration: 17800 nM
The estimate for compound 4 lay 4.5-fold (0.65 log units) below the measured number, outside the stated range (above it).
By their numbers in this assay, from the lowest: compounds 2, 1 and 3 (each within the scatter of the next, the first and the last beyond it); then compound 4.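

Among the compounds shown here, the ring exchange on a saturated chain carbon bound to a double-bonded chain carbon gives a 4.7-fold higher number from compound 1 to compound 4 (0.67 log units; beyond the scatter) in this assay and is the only step between compounds that differ in one place. For the compounds shown here, the number at this position therefore responds to the identity of the ring, and the entering ring, with 2 hydrogen-bond donors in place of 1 and one more oxygen, goes with weaker inhibition, something the earlier compounds could not show. No measurement at hand bears on the reason for this step.

As far as these compounds go, whether the step follows from the added oxygen alone or from the ring as a whole remains open. Also open, from the compounds shown here alone, is how an amine or a carboxylic acid at this place, or a longer chain, would read.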